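A few compounds are considered here, and "the series" means these few. Any claim that something is new, unique, unknown or untested is made for them only; others in the source may bear on it.

Compound 1, `CCCCCCCCCCCCCCCCCCOC[C@H](COP(=O)(O)O[C@H]1[C@@H](O)[C@@H](O)[C@H](O)C[C@H]1O)OC`, compound 2, `CCCCCCCCCCCCCCCCCCOC[C@H](COP(=O)(O)O[C@@H]1[C@H](O)[C@H](CO)[C@@H](O)[C@H](O)[C@@H]1O)OC`, and compound 3, `CCCCCCCCCCCCCCCCCCOC[C@H](COC(=O)O[C@@H]1[C@H](O)[C@H](CO)[C@@H](O)[C@H](O)[C@@H]1O)OC`, share a long alkyl ether chain on a glycerol-like backbone that carries a polyhydroxylated ring through a linking group. In a functional assay on HT-29 cells (Homo sapiens) for inhibition (on this read-out higher numbers stand for weaker inhibition and lower numbers for stronger inhibition), compound 1 gives 2100 nM. In this assay compound 2 gives 4500 nM, and in this assay compound 3 gives 10000 nM. Compound 3 thus has the highest of the three numbers; the difference between the cores of compound 2 and compound 3 is not broken down here.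

Compound 1 arises from compound 2 through (hydrogen in place of hydroxymethyl on a saturated ring carbon), and this gave a 2.1-fold lower number from compound 2 to compound 1 (0.33 log units; beyond the scatter). Compound 4, `CCCCCCCCCCCCCCCCCCOC[C@H](COC(=O)O[C@H]1[C@@H](O)[C@@H](O)[C@H](O)C[C@H]1O)OC`, has not yet been measured. It stands to compound 3 as compound 1 stands to compound 2: the change is hydrogen in place of hydroxymethyl on a saturated ring carbon, and its place reads the same as before, so it is the same change, only made on the other core.

With a single earlier instance to go on, the estimate is that the same change will move the number in the same direction and by about the same amount, because the earlier step of a 2.1-fold lower number from compound 2 to compound 1 (0.33 log units; beyond the scatter) was modest but beyond the scatter. Compound 4 is therefore expected to give 5000 nM in this assay, with a plausible range from 2500 nM to 10000 nM. The expected step for compound 4 is a 2.0-fold lower number from compound 3 to compound 4 (0.30 log units; within the scatter).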

Compound 4, half-maximal inhibitory concentration: 2500 nM
For compound 4 the middle estimate is 2.0-fold (0.30 log units) above the measured one, and the stated range covers the measured number.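

In this assay, putting hydrogen in place of hydroxymethyl on the core of compound 3 gave a 4.0-fold lower number from compound 3 to compound 4 (0.60 log units; beyond the scatter), so the change moved the number in the same direction on the second core as on the first, and the two steps do not differ in size by more than the measurements can resolve: the same change on two cores in this assay, a 2.1-fold lower number (0.33 log units; beyond the scatter) from compound 2 to compound 1 and a 4.0-fold lower number (0.60 log units; beyond the scatter) from compound 3 to compound 4, 1.9-fold (0.27 log units) apart, within the scatter of two such steps. Within these two pairs, then, the change carried from one core to the other, and the apparently larger second step should not be read as a stronger effect on that core. For the compounds shown here, this rests on only two pairs in a single cell assay, however, so it does not establish a rule for other cores, and it says nothing about why removing the hydroxymethyl group lowers the number.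

The compounds shown leave open whether the same change would hold on a core joined through another linking group, such as an amide, or on one with a shorter chain in place of the long alkyl ether chain. They also leave open what would happen if the hydroxymethyl group gave way to something other than hydrogen, such as a methyl group, an amine or a carboxylic acid.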